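Shifting a Hydroxyl Group on a Shared Core

The source may hold more compounds than are shown below. What is called first, only, known or untested is meant among the compounds shown, and "the series" means these compounds.

Three compounds built on one shared core were examined in a functional assay on T47D cells (Homo sapiens) for cytotoxicity, read by CCK-8 assay and cell counting, with a stated time of 2 days; on this read-out lower numbers stand for stronger inhibition and higher numbers for weaker inhibition. Compound 1 `Oc1ccc(-c2cc(-c3ccc(Cl)cc3)nc(-c3cccnc3)c2)cc1` gives 29300 nM in this assay. Compound 3 `Oc1ccc(-c2cc(-c3cccs3)nc(-c3ccccc3Cl)c2)cc1` gives 5870 nM in this assay. Compound 2 `Oc1cccc(-c2cc(-c3ccncc3)nc(-c3cccc(Cl)c3)c2)c1` has no number in this assay; its result is reported as "not determined" (no result reported). Of the two numbers available, compound 1 stands highest, and its distance to compound 3 lies beyond the scatter of repeated measurements.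

The unmeasured compound 4 `Oc1cccc(-c2cc(-c3ccc(Cl)cc3)nc(-c3cccnc3)c2)c1` differs from compound 1 in one place: 3-hydroxyphenyl in place of 4-hydroxyphenyl on an aromatic carbon. Going by the values given here, no pair of measured compounds shows this exact change on its own, and compound 2, which also carries a 3-hydroxyphenyl group, has no number to compare against. The effect of the change therefore cannot be read from the measured compounds and has to be taken from the change itself. The step from compound 1 to compound 4 is expected to be a 1.3-fold lower number from compound 1 to compound 4 (0.12 log units; within the scatter), that is, small and not clearly beyond the scatter, with at most a slight lean toward a lower number.

Because compound 1 gives 29300 nM, compound 4 is estimated to stay in the same weak region at 22000 nM in this assay, with an expected range from 6000 nM to 70000 nM.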

Compound 4, half-maximal inhibitory concentration: 18100 nM
The estimate for compound 4 lay 1.2-fold (0.08 log units) above the measured number; measured number inside the range.
By their numbers in this assay, from the lowest: compound 3; then compounds 4 and 1 (each within the scatter of the next).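

In this assay, going by these compounds alone, the change from 4-hydroxyphenyl to 3-hydroxyphenyl, opposite the ring nitrogen of the shared core, gives a 1.6-fold lower number from compound 1 to compound 4 (0.21 log units; within the scatter) and is the first direct reading of this change, since compound 2, the only earlier compound with a 3-hydroxyphenyl group, has no number. The step shows that on the core of compound 1, with its 4-chlorophenyl and pyridin-3-yl groups, the two placements of the hydroxyl cannot be told apart in this read-out, and both compounds remain in the same weak region of the numbers shown. Nothing available here offers an explanation for this result.

The compounds shown leave open whether the hydroxyl matters at all at this position, as neither a methoxy group, an amine nor a carboxylic acid appears on this phenyl ring, and an unsubstituted phenyl ring is also absent. They also leave open whether the same change would read alike on a core carrying other groups, such as the thiophene and 2-chlorophenyl groups of compound 3.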